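The compounds below may be only part of what the source reports. "The series", "measured", "known", "first", "only" and "open" are said of these compounds alone.

Compound 1 `Cc1cccc(/C=N/Nc2ncc3c(n2)n(C2CCCC2)c(=O)c(=O)n3C)c1` is the weakest of the three measured compounds in a functional assay on PC-3 cells (Homo sapiens) for antiproliferative activity, read by MTT assay (on this read-out higher numbers stand for weaker inhibition and lower numbers for stronger inhibition), where compound 1 gives 53600 nM. Compound 2 `Cn1c(=O)c(=O)n(C2CCCC2)c2nc(N/N=C/c3ccc(C(F)(F)F)cc3)ncc21` gives 23600 nM, and compound 3 `Cn1c(=O)c(=O)n(C2CCCC2)c2nc(N/N=C/c3cccc(Cl)c3Cl)ncc21` gives 17200 nM. Both steps away from compound 1 lowered the number: a 2.3-fold lower number from compound 1 to compound 2 (0.36 log units; beyond the scatter) and a 3.1-fold lower number from compound 1 to compound 3 (0.49 log units; beyond the scatter). Between the other two, the step of a 1.4-fold lower number from compound 2 to compound 3 (0.14 log units; within the scatter) is too small to count.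

Compound 4 `Cn1c(=O)c(=O)n(C2CCCC2)c2nc(N/N=C/c3cccs3)ncc21` has not been measured. It differs from compound 1 in one place: thiophen-2-yl in place of 3-methylphenyl on a carbon with a double bond to nitrogen. Among the measured compounds shown here, no measured step exchanges the six-membered aromatic ring for a five-membered one, so the steps from compound 1 to compound 2 and to compound 3 are the only guidance; on both occasions replacing 3-methylphenyl lowered the number modestly, but the groups that entered there are unlike thiophen-2-yl. The expectation is therefore a modest downward step or none beyond the scatter, with wide uncertainty. Compound 4 is expected to move by a 1.8-fold lower number from compound 1 to compound 4 (0.25 log units; within the scatter). Compound 4 is thus expected to give 30000 nM in this assay, most likely between 12000 nM and 80000 nM.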

Compound 4, half-maximal inhibitory concentration: 75600 nM
The estimate for compound 4 lay 2.5-fold (0.40 log units) below the measured number; the measured number falls inside the stated range.
By their numbers in this assay, from the lowest: compounds 3 and 2 (each within the scatter of the next); then compounds 1 and 4 (each within the scatter of the next).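

Thiophen-2-yl at this place, on a carbon with a double bond to nitrogen, does not repeat what the two earlier replacements of 3-methylphenyl did: in this assay the comparison gives a 1.4-fold higher number from compound 1 to compound 4 (0.15 log units; within the scatter) and so leaves it indistinguishable from the group it replaces. Set against the other entering groups, it gives a 3.2-fold higher number from compound 2 to compound 4 (0.51 log units; beyond the scatter) for 4-(trifluoromethyl)phenyl and a 4.4-fold higher number from compound 3 to compound 4 (0.64 log units; beyond the scatter) for 2,3-dichlorophenyl, so this position does respond to the group placed there, but replacing 3-methylphenyl does not by itself lower the number, and compound 4 is the case that goes against the earlier impression. Among the compounds shown, the lower numbers belong only to the two substituted six-membered rings carrying halogen atoms, and nothing available here explains why the entering groups separate in this way.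

On these data alone, whether a furan-2-yl group, with oxygen in place of the sulfur, or a thiophen-3-yl group would stay level with compound 4 remains open. So does the question of whether a pyridin-3-yl ring, or a phenyl ring bearing a single chlorine or an amine, would fall with compound 2 and compound 3 or with compound 1 and compound 4.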